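The source may hold more compounds than are shown below. What is called first, only, known or untested is meant among the compounds shown, and "the series" means these compounds.

Values in a functional assay on the whole organism (Hindlimb, strain albino) with Mus musculus as the target, in the maximal electroshock model, with a stated time of 0.5 h (on this read-out lower numbers stand for an effect already at smaller amounts and higher numbers for an effect only at larger amounts of compound), so far:

- Compound 1 `COc1ccc(/C=C/C(=O)Nc2nc3ccc([N+](=O)[O-])cc3s2)cc1` gives 315 umol/kg
- Compound 2 `O=C(/C=C/OC1=CC=C1)Nc1nc2ccc([N+](=O)[O-])cc2s1` gives 597 umol/kg
- Compound 3 `Cc1ccc2nc(NC(=O)/C=C/c3ccc(O)cc3)sc2c1` gives 271 umol/kg

In this assay compound 3 lies within the scatter of compound 1 and beyond the scatter of compound 2, whose number is higher. Compound 4 `O=C(/C=C/c1ccc(O)cc1)Nc1nc2ccc([N+](=O)[O-])cc2s1` follows from compound 3 by one exchange, nitro in place of methyl on an aromatic carbon. Among the measured compounds shown here, no measured pair tests this exchange alone. For the measured compounds named here, the one measured step, a 1.9-fold higher number from compound 1 to compound 2 (0.28 log units; within the scatter), keeps the nitro group and changes a different group, so it bears on this exchange only indirectly. The closest guide is compound 1, which carries the nitro group and stands at 315 umol/kg, although it also differs from compound 4 in a second group. A step beyond the scatter is therefore not expected in this assay, and no direction can be favoured with confidence. The expected change is a 1.2-fold higher number from compound 3 to compound 4 (0.07 log units; within the scatter). For compound 4 the estimate is 320 umol/kg. The expected range for compound 4 runs from 150 umol/kg to 680 umol/kg.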

Compound 4, dose for half-maximal effect: 382 umol/kg
Estimate against measurement, compound 4: 1.2-fold (0.08 log units) below, and the stated range covers the measured number.
By their numbers in this assay, from the lowest: compounds 3, 1, 4 and 2 (each within the scatter of the next, the first and the last beyond it).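

In this assay the exchange of methyl for nitro on the aromatic carbon can now be read on its own, and it gives a 1.4-fold higher number from compound 3 to compound 4 (0.15 log units; within the scatter) with no step beyond the scatter at this position. Among the compounds shown here, the other end of compound 4 can also be read for the first time: hydrogen in place of methyl on the oxygen on the aromatic ring gives a 1.2-fold higher number from compound 1 to compound 4 (0.08 log units; within the scatter) and the six-membered aromatic ring in place of the four-membered ring gives a 1.6-fold lower number from compound 2 to compound 4 (0.19 log units; within the scatter) so that neither exchange moves the number beyond the scatter. Nothing in hand accounts for the size of these steps.

The compounds shown leave open how an amine or a carboxylic acid on that aromatic carbon would read. They also leave open whether a longer chain on the oxygen would stay within the scatter.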